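The source may hold more compounds than are shown below. What is called first, only, known or untested is meant among the compounds shown, and "the series" means these compounds.

Among the measured compounds shown here, compound 3 `C=C(Br)C(=O)Nc1cccc(-c2cn3nc(-c4ccc(C)cc4)sc3n2)c1` gives 1700 nM in a functional assay on CCRF-CEM cells (Homo sapiens) for inhibition, read by cell counting, with a stated time of 3 days (a lower number here means a stronger inhibitor, a higher number a weaker inhibitor), the second highest of the three numbers measured so far; compound 1 `C=C(Br)C(=O)Nc1cccc(-c2cn3nc(-c4ccccc4)sc3n2)c1` gives 960 nM and compound 2 `C=C(Br)C(=O)Nc1cccc(-c2cn3nc(Cc4ccc(Cl)cc4)sc3n2)c1` gives 3300 nM, and both of these lie within the scatter of the number for compound 3. Compound 4 `C=C(Br)C(=O)Nc1cccc(-c2cn3nc(-c4cccc(OC)c4)sc3n2)c1` differs from compound 3 by 3-methoxyphenyl in place of 4-methylphenyl on an aromatic carbon. For the measured compounds named here, the steps that bear on this change are a 1.8-fold higher number from compound 1 to compound 3 (0.25 log units; within the scatter), a change of one substituent on the same aryl ring, and a 3.4-fold higher number from compound 1 to compound 2 (0.54 log units; beyond the scatter), the only step beyond the scatter. A swap of one aryl substituent for another is therefore expected to move this assay only a little, a 1.1-fold lower number from compound 3 to compound 4 (0.05 log units; within the scatter). Compound 4 is estimated at 1500 nM, with a range from 600 nM to 4000 nM.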

Compound 4, half-maximal inhibitory concentration: 1200 nM
Compound 4: the middle estimate sits 1.3-fold (0.10 log units) above what was measured, within the range that was stated.
By their numbers in this assay, from the lowest: compounds 1, 4, 3 and 2 (each within the scatter of the next, the first and the last beyond it).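

In this assay, the 3-methoxyphenyl group, which brings an oxygen and a hydrogen-bond acceptor to this position, stays within the scatter of both aryl neighbours, with a 1.4-fold lower number from compound 3 to compound 4 (0.15 log units; within the scatter) and a 1.3-fold higher number from compound 1 to compound 4 (0.10 log units; within the scatter). The change from 4-chlorobenzyl goes beyond the scatter, with a 2.8-fold lower number from compound 2 to compound 4 (0.44 log units; beyond the scatter), although compound 3 remains within the scatter of compound 2. Nothing available explains these numbers. From the compounds shown here alone, it remains open whether an amine or a carboxylic acid on the phenyl ring would also stay within the scatter. The effect of a longer chain at this position is open too.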